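The source may report more compounds than this note shows. Statements on the series, on what has been measured and on what is new or still open speak of the compounds shown alone.

Measured compounds:
- compound 1, `CN(C)CCNc1ccnc2cc(OCc3ccc(F)cc3)ccc12`: 370 nM
- compound 2, `CN(C)CCNc1ccnc2cc(OCc3ccccc3)ccc12`: 1980 nM
- compound 3, `C=CCOc1ccc2c(NCCN(C)C)ccnc2c1`: 860 nM

In a functional assay on HCT-116 cells (Homo sapiens) for cytotoxicity, read by MTT assay, with a stated time of 48 h (on this read-out higher numbers stand for weaker inhibition and lower numbers for stronger inhibition), compound 1 stands lowest of the three. Its nearest neighbour is compound 3, reached by a 2.3-fold higher number from compound 1 to compound 3 (0.37 log units; beyond the scatter), and its furthest is compound 2, reached by a 5.4-fold higher number from compound 1 to compound 2 (0.73 log units; beyond the scatter); between those two, a 2.3-fold lower number from compound 2 to compound 3 (0.36 log units; beyond the scatter). All three of these steps alter the group carried on the oxygen of the shared core and leave the amine-bearing side chain untouched.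

Compound 4, `CN(C)CCCNc1ccnc2cc(OCc3ccc(F)cc3)ccc12`, is reached from compound 1 by a change on the other side of the core: (dimethylamino)methyl in place of dimethylamino on a saturated chain carbon, two bonds along the chain from a nitrogen on an aromatic ring. Read one bond further out, the 2-(dimethylamino)ethyl becomes a 3-(dimethylamino)propyl. Among the measured compounds shown here, none of the measured steps bears on this chain: the three compounds all share the same 2-(dimethylamino)ethyl side chain, so nothing in the data shows how lengthening it moves the number in this assay. With no evidence either way, the expected step is a 1.2-fold higher number from compound 1 to compound 4 (0.09 log units; within the scatter), not beyond the scatter, held with a wide range. Compound 4 is therefore estimated at 450 nM in this assay, between 150 nM and 1500 nM.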

Compound 4, half-maximal inhibitory concentration: 740 nM
Compound 4: middle estimate off by 1.6-fold (0.22 log units), on the low side, and the stated range covers the measured number.
By their numbers in this assay, from the lowest: compounds 1, 4 and 3 (each within the scatter of the next, the first and the last beyond it); then compound 2.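

Among the compounds shown here, compound 4 gives the first reading on the amine-bearing side chain, where every earlier step altered the group on the oxygen: in this assay the change from 2-(dimethylamino)ethyl to 3-(dimethylamino)propyl gives a 2.0-fold higher number from compound 1 to compound 4 (0.30 log units; within the scatter). This assay therefore cannot tell the two chain lengths apart for this one pair, so the position takes the added carbon without a step that stands clear of the usual scatter, whereas the steps on the oxygen side all lie beyond it. Nothing measured here bears on how this change acts on the cells, so the result stands as a plain observation.

The compounds shown leave open whether a longer chain, such as 4-(dimethylamino)butyl, or a diethylamino group or a primary amine in place of the dimethylamino at the chain end, would also stay within the scatter of compound 1. Also open, going by these compounds, is whether the same lengthening of the chain would read alike on compound 2 and compound 3, which carry other groups on the oxygen.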